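Chloro for Methoxy: Clearance in a Small Aryl Series

The source may hold more compounds than are shown below. What is called first, only, known or untested is meant among the compounds shown, and "the series" means these compounds.

Compound 1 `c1ccc(C2Cc3nccn3C2)cc1`: 15 mL.min-1.g-1; < 7 mL.min-1.g-1 (2 entries)
Compound 2 `COc1ccc(C2Cc3nccn3C2)cc1`: 30 mL.min-1.g-1
Compound 3 `N#Cc1ccccc1C1Cc2nccn2C1`: < 7 mL.min-1.g-1

Three compounds sharing one core have been run in an in vitro ADME assay on microsomes from liver (Homo sapiens) for metabolic stability; on this read-out higher numbers stand for fast clearance and lower numbers for slow clearance. Compound 2 stands alone in giving a single number, 30 mL.min-1.g-1, and it is the highest figure shown. Compound 1 was run more than once, and its entries the several entries of compound 1 in this assay, 15 mL.min-1.g-1; < 7 mL.min-1.g-1 (2 entries) mix a number with a limit of the assay rather than a number. Compound 3 gives only a limit of the assay, < 7 mL.min-1.g-1, one of the values sitting at that limit (the limit of < 7 mL.min-1.g-1 in this assay, at which 1 of the 3 values shown sits).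

Compound 4 `Clc1ccc(C2Cc3nccn3C2)cc1` has not yet been run in this assay. It differs from compound 2 by chloro in place of methoxy on an aromatic carbon. For the measured compounds named here, no measured pair shows that change, so the size of the step can only be expected. Going by the values given here, compound 1, lacking any group at that carbon, sits at or near the limit, while compound 2 with methoxy gives the one clear number; on that basis the step from compound 2 to compound 4 is expected to run downward, though it may well stay within the usual scatter. Compound 4 is thus estimated at 13 mL.min-1.g-1 in this assay, between 6 mL.min-1.g-1 and 30 mL.min-1.g-1, with a fair chance that only a limit is reported.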

Compound 4, intrinsic clearance in microsomes: 32 mL.min-1.g-1
The estimate for compound 4 lay 2.5-fold (0.39 log units) below the measured number; the whole stated range lies below it.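

In this assay, chloro in place of methoxy on an aromatic carbon, para to a group of 8 heavy atoms, gives a 1.1-fold higher number from compound 2 to compound 4 (0.03 log units; within the scatter), so the two groups cannot be told apart at this carbon on this read-out. Methoxy brings a hydrogen-bond acceptor and chloro brings none, yet compound 4 gives 32 mL.min-1.g-1 and compound 2 gives 30 mL.min-1.g-1, so compound 2 no longer stands alone with a clear number, and that number can no longer be tied to methoxy in particular. The comparison with no group at that carbon stays unsettled in compound 1, whose entries mix a number with a limit of the assay: the several entries of compound 1 in this assay, 15 mL.min-1.g-1; < 7 mL.min-1.g-1 (2 entries)

As far as these compounds go, the steps from compound 1 to compound 2 and to compound 4 cannot be read, so how far either group stands from the compound without a group at that carbon remains open. Also open, from the compounds shown here alone, is whether an amine, a carboxylic acid or a longer chain such as ethoxy at the same carbon would fall in line with compound 2 and compound 4 or give a different number.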